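This account rests on a few compounds, and the source may have more. Where it says the series, first, only, none or still open, it means among the compounds named here.

Within the data shown here, compound 1 `CC1(C)CCN1S(=O)(=O)c1cncc(-c2ccn3nc(N)nc3c2)c1` is one of two compounds measured in an assay on isolated protein for inhibition of phosphatidylinositol 4,5-bisphosphate 3-kinase catalytic subunit beta isoform (Homo sapiens); a lower number here means a stronger inhibitor, a higher number a weaker inhibitor; compound 1 gives 50100000 nM. Compound 2 `Nc1nc2cc(-c3cncc(S(N)(=O)=O)c3)ccn2n1`, which carries amino in place of 2,2-dimethylazetidin-1-yl on the sulfonyl sulfur, gives 39800000 nM; the step of a 1.3-fold lower number from compound 1 to compound 2 (0.10 log units; within the scatter) lies within the scatter, so the two numbers cannot be told apart. Compound 3 `Nc1nc2cc(-c3cncc(S(=O)(=O)Nc4ccccc4)c3)ccn2n1` is not yet measured. It differs from compound 1 as follows: anilino in place of 2,2-dimethylazetidin-1-yl on a sulfonyl sulfur. Among the measured compounds shown here, the one measured step on that sulfonyl sulfur, a 1.3-fold lower number from compound 1 to compound 2 (0.10 log units; within the scatter), replaced the same leaving group with amino and left the number essentially where it was; no step to anilino has been measured, and both measured numbers sit very high. On that basis no step beyond the scatter is expected in this assay, a 1.1-fold lower number from compound 1 to compound 3 (0.05 log units; within the scatter). The expected value for compound 3 is 45000000 nM, with a range from 10000000 nM to 200000000 nM.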

Compound 3, half-maximal inhibitory concentration: 31600000 nM
Compound 3: middle estimate off by 1.4-fold (0.15 log units), on the high side; measured number inside the range.
By their numbers in this assay, from the lowest: compounds 3, 2 and 1 (each within the scatter of the next).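

On the sulfonyl sulfur, anilino joins amino and 2,2-dimethylazetidin-1-yl in this assay, and a 1.6-fold lower number from compound 1 to compound 3 (0.20 log units; within the scatter) gives no separation from the earlier number. Phenyl in place of hydrogen on the sulfonamide nitrogen also leaves the number unresolved, with a 1.3-fold lower number from compound 2 to compound 3 (0.10 log units; within the scatter), so all three groups on this sulfur lie within the scatter of one another, and the flat picture now covers a ring-bearing substituent as well as the unsubstituted sulfonamide. No measured evidence on the series bears on this flat result.

Still open, going by these compounds, is whether any other group on this sulfur, such as a piperazine or a chain ending in a carboxylic acid, would separate from these three numbers. Also open, on these data alone, is whether a change elsewhere on the shared core would bring the numbers down from this very high level in this assay.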